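A few compounds are considered here, and "the series" means these few. Any claim that something is new, unique, unknown or untested is made for them only; others in the source may bear on it.

Measured so far in an assay on Sf9 cells for inhibition of protein deacetylase HDAC6 (Homo sapiens), read by fluorescence, with a stated time of 40 min; on this read-out lower numbers stand for stronger inhibition and higher numbers for weaker inhibition:
compound 1 `O=C(NO)c1ccc(NCc2nc(-c3ccccc3)nn2-c2ccccc2Cl)cc1`: 669 nM
compound 2 `O=C(NO)c1ccc(NCc2nc(-c3cccc(Cl)c3)nn2-c2ccccc2)cc1`: 115 nM
compound 3 `O=C(NO)c1ccc(NCc2nc(-c3ccc(Cl)cc3)nn2-c2ccccc2)cc1`: 181 nM

Compound 3 stands second highest of the three numbers. Its nearest neighbour is compound 2; the move a 1.6-fold higher number from compound 2 to compound 3 (0.20 log units; within the scatter) is within the scatter, so no order between these two can be read. Compound 1 is furthest, with a number beyond the scatter higher than that of compound 3.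

Compound 4 `O=C(NO)c1ccc(NCc2nc(-c3ccccc3)nn2-c2ccccc2)cc1` differs from compound 3 by hydrogen in place of chloro on an aromatic carbon. Within the data shown here, no measured pair shows a chloro being removed from that ring; the only single-change step in hand, from compound 2 to compound 3, moves the chloro on the same ring and stays within the scatter. This gives no basis for expecting a step beyond the scatter in this assay in either direction, and the estimate for compound 4 is set close to compound 3, widened for the lack of a direct comparison. Expected step: a 1.3-fold higher number from compound 3 to compound 4 (0.12 log units; within the scatter). The value of compound 4 is estimated at 240 nM, with a range from 100 nM to 600 nM.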

Compound 4, half-maximal inhibitory concentration: 112 nM
Beside the measured number, compound 4's estimate is 2.1-fold (0.33 log units) above it; low and high end bracket the measured number.
By their numbers in this assay, from the lowest: compounds 4, 2 and 3 (each within the scatter of the next); then compound 1.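

In this assay the removal of chloro from the 4-chlorophenyl group gives a 1.6-fold lower number from compound 3 to compound 4 (0.21 log units; within the scatter) and the same removal from the 3-chlorophenyl group gives a 1.0-fold lower number from compound 2 to compound 4 (0.01 log units; within the scatter) with neither step showing that a chloro at these two places on this ring alters the number. Among these compounds, the chloro on the other phenyl ring reads differently, since hydrogen in its place gives a 6.0-fold lower number from compound 1 to compound 4 (0.78 log units; beyond the scatter) as the only one of these three steps beyond the scatter. No measured evidence bearing on the cause of either outcome is available.

From the compounds shown here alone, whether a methoxy group, an amine or a carboxylic acid at the para place on this ring would move the number beyond the scatter remains open. Also open, going by these compounds, is how such groups would read on the other phenyl ring, where chloro and hydrogen already separate.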